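Cyclohexyl for Butyl on the Amine Nitrogen

The compounds below may be only part of what the source reports. "The series", "measured", "known", "first", "only" and "open" are said of these compounds alone.

Three compounds built on a shared core differ only in the group on the amine nitrogen. Compound 1 `CCCNC(=C\C(=O)/C=C/c1ccc(O)c(OC)c1)/C=C/c1ccc(O)c(OC)c1` gives in a functional assay for inhibition, read by spectrophotometry, with a stated time of 30 min, tested at 1 uM (on this read-out higher numbers stand for more inhibition at the one concentration tested (going by the name of the read-out) and lower numbers for less inhibition), a read-out of 0.1%. Compound 2 `CCC(C)NC(=C\C(=O)/C=C/c1ccc(O)c(OC)c1)/C=C/c1ccc(O)c(OC)c1` gives in this assay 0.13%, and compound 3 `CCCCNC(=C\C(=O)/C=C/c1ccc(O)c(OC)c1)/C=C/c1ccc(O)c(OC)c1` gives in this assay 0.08%. Compound 3 holds the lowest of the three numbers, yet the steps of a number 0 percentage points lower from compound 1 to compound 3 (within the scatter) and a number 0.1 percentage points lower from compound 2 to compound 3 (within the scatter) both fall within the scatter, as does a number 0 percentage points higher from compound 1 to compound 2 (within the scatter), so the three compounds cannot be told apart on this read-out. Compound 4 `COc1cc(/C=C/C(=O)/C=C(/C=C/c2ccc(O)c(OC)c2)NC2CCCCC2)ccc1O` takes the next step from compound 3: cyclohexyl in place of butyl on an amine nitrogen. All three measured steps concern the group on the same amine nitrogen, including the exchange of butyl for sec-butyl, and none of them moved the read-out beyond the scatter. It is therefore expected that the step of a number 0 percentage points higher from compound 3 to compound 4 (within the scatter) also stays within the scatter. Compound 4 is estimated at 0.1%, with a range from 0% to 5%.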

Compound 4, a percentage reported as inhibition, at one concentration (the size of the read-out at that concentration, not a potency): 0.13%
Compound 4: middle estimate off by 0 percentage points, on the low side; the range from low to high includes it.
By their numbers in this assay, from the lowest: compounds 3, 1, 2 and 4 (each within the scatter of the next).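

Within the data shown here, with cyclohexyl, a six-membered non-aromatic ring of carbon only stands on this amine nitrogen for the first time, where the earlier compounds carried only groups with no ring. In this assay, the ring leaves the read-out within the scatter of all three of those groups, with a number 0.1 percentage points higher from compound 3 to compound 4 (within the scatter), no change at the digits printed from compound 2 to compound 4 (within the scatter) and a number 0 percentage points higher from compound 1 to compound 4 (within the scatter), so neither ring formation nor the larger carbon count of 6 separates compound 4 from the others. No supporting information accounts for this lack of separation.

The compounds shown leave open whether a phenyl ring, a carboxylic acid or a further amine on this nitrogen would move the read-out beyond the scatter. They also leave open whether a change away from this nitrogen, such as replacing the methoxy groups of the shared core with hydrogen, would do so.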